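Moving the Pyrazole Attachment Point on a Shared Core

This account rests on a few compounds, and the source may have more. Where it says the series, first, only, none or still open, it means among the compounds named here.

Compound 1, `c1cc(-c2ccn[nH]2)c2c(c1)C(c1ncc[nH]1)CC2`, gives 336 nM.
Compound 3, `c1ccc2c(c1)CCCC2c1ncc[nH]1`, gives 364 nM.
Compound 2, `CS(=O)(=O)Nc1cccc2c1CCCC2c1ncc[nH]1`, gives > 10000 nM; > 10000 nM; > 10000 nM (3 entries), which is a limit of the assay and not a number.

These three compounds were measured in a functional assay on CHO cells for agonist activity at Alpha-1D adrenergic receptor (Homo sapiens), read by FLIPR and calcium flux; a lower number here means that less compound is needed, a higher number that more compound is needed for the effect. Among the two compounds with a number, compound 1 stands lowest, but its nearest neighbour, compound 3, lies within the usual scatter of the measurement, so the two cannot be told apart on these figures. Compound 2 gives only a limit and offers no number to compare.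

Compound 4, `c1cc(-c2cn[nH]c2)c2c(c1)C(c1ncc[nH]1)CC2`, has not yet been measured. It keeps every atom of compound 1 and differs only in how they are joined: 1H-pyrazol-4-yl in place of 1H-pyrazol-5-yl on an aromatic carbon. Since compound 3, which carries no pyrazole at all, gives 364 nM, the pyrazol-5-yl of compound 1 appears to add little, and the pyrazol-4-yl is expected to behave alike. The step of a 1.2-fold higher number from compound 1 to compound 4 (0.08 log units; within the scatter) is expected to be none beyond the scatter. Compound 4 is therefore expected to give about 400 nM, with a range from 150 nM to 1500 nM.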

Compound 4, half-maximal effective concentration: 319 nM
The estimate for compound 4 lay 1.3-fold (0.10 log units) above the measured number; the measured number falls inside the stated range.
By their numbers in this assay, from the lowest: compounds 4, 1 and 3 (each within the scatter of the next).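

In this assay, putting 1H-pyrazol-4-yl in place of 1H-pyrazol-5-yl gives a 1.1-fold lower number from compound 1 to compound 4 (0.02 log units; within the scatter), so the two ways of joining the pyrazole to this aromatic carbon cannot be told apart. The earlier compounds shown here could not show this, since only one of them carried a pyrazole and none offered a second way of joining it. No measurement shown here offers an explanation for this result. 

Still open is how this position responds to a different kind of group, such as an amine, a carboxylic acid or a phenyl ring, since only these two pyrazoles are shown on the shared core. Compound 3 differs from compound 1 in more than one place, so what the pyrazole itself contributes also remains unsettled.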